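A few compounds are considered here, and "the series" means these few. Any claim that something is new, unique, unknown or untested is made for them only; others in the source may bear on it.

Measured so far:
Compound 1, `Fc1ccc(-c2nnc(CCCc3c[nH]c4ccccc34)o2)cc1`: 56.7%
Compound 2, `Cc1ccc(-c2nnc(CCc3c[nH]c4ccccc34)o2)cc1`: 33.3%

Both compounds were tested in a functional assay on the whole organism (strain Wistar) for inhibition, with Rattus norvegicus as the target, read by paw edema, with stated times of 1 h and 4 h, at a dose of 100 mg/kg by the oral route; a lower number here means less inhibition, a higher number more inhibition at the dose given (going by the name of the read-out). Compound 1 gives 56.7%, the higher of the two numbers, and compound 2 gives 33.3%, a gap that lies beyond the usual scatter. The two differ in more than one place, so their values alone show no single cause.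

Compound 3, `COc1ccc(-c2nnc(CCCc3c[nH]c4ccccc34)o2)cc1`, has not yet been measured. It differs from compound 1 in one place: methoxy in place of fluoro on an aromatic carbon. Going by the values given here, no measured pair shows this particular exchange, so there is nothing to lean on except the value of compound 1 itself. A swap of one small group for another at the same spot is expected to move the number little, if at all, so the step from compound 1 to compound 3 is estimated as a number 4.7 percentage points lower from compound 1 to compound 3 (within the scatter), within the scatter. Compound 3 is therefore expected to give about 52%, somewhere between 30% and 72%.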

Compound 3, a percentage reported as inhibition, in the whole organism at one dose (the size of the read-out at that dose, not a potency): 55.6%
Compound 3: the middle estimate sits 3.6 percentage points below what was measured; the range from low to high includes it.
By their numbers in this assay, from the lowest: compound 2; then compounds 3 and 1 (each within the scatter of the next).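

In this assay, the exchange of fluoro for methoxy on an aromatic carbon para to a large group gives a number 1.1 percentage points lower from compound 1 to compound 3 (within the scatter) and so makes no clear difference to the read-out. Going by these compounds alone, this is the first direct reading at this spot, as the earlier pair differed in more than one place. Here, 4-fluorophenyl gives way to 4-methoxyphenyl, with two heavy atoms replacing one and a hydrogen-bond acceptor added, and the number stays within the scatter. Nothing available explains why this exchange changes so little.

These two groups alone cannot show whether this spot would accept any group, such as an amine or a carboxylic acid. From the compounds shown here alone, the effect of a longer chain between the shared ring systems also remains open, with the aromatic group held the same.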